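Amide in place of the benzyl group on the shared core

The source may report more compounds than this note shows. Statements on the series, on what has been measured and on what is new or still open speak of the compounds shown alone.

Measured compounds:
compound 1 `CN(C)CCN1CCN(c2nc(-c3ccccn3)nc3c2CN(Cc2ccc(F)cc2)CC3)CC1` in an assay on FRT cells with Cystic fibrosis transmembrane conductance regulator variant F508del (Homo sapiens) as the target, read by fluorescence, with a stated time of 25 min; on this read-out higher numbers stand for larger maximal responses and lower numbers for smaller maximal responses: "not active" (no number reported)
compound 2 `Fc1ccc(CN2CCc3nc(-c4ccccn4)nc(NCCN4CCCC4)c3C2)cc1` in this assay: 40%

Compound 1 is reported as "not active" (no number reported) in this assay, so no single number stands for it; it sits at the bottom of what the read-out can show. Compound 2 gives 40% in this assay. Going by the values given here, no step between compound 1 and compound 2 is computed, and the two values show only that compound 2 reaches a measurable maximal response where compound 1 does not.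

Compound 3 `CN(C)CCN1CCN(c2nc(-c3ccccn3)nc3c2CN(C(=O)c2ccccc2)CC3)CC1` differs from compound 1 in one place: benzoyl in place of 4-fluorobenzyl on an amine nitrogen in a ring. Nothing measured follows this change, so no step size can be read off. Because compound 1 stands at "not active" (no number reported), any number for compound 3 in this assay would be a rise, but none beyond the scatter is expected, and a repeat of a non-active report is about as likely as a small measurable response.

Compound 3 is expected to give 10%, in a range from 0% to 35%.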

Compound 3, largest response reached (Emax), in percent of the reference or control that the assay uses: "not active" (no number reported)
No number was reported for compound 3, so the estimate cannot be set against anything.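

In this assay compound 1 gives "not active" (no number reported) and compound 3 gives "not active" (no number reported) and so no step can be read for benzoyl in place of 4-fluorobenzyl. The compounds shown leave open whether any group on this ring amine nitrogen gives a measurable maximal response with this core. No evidence bears on this result.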